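Swapping methoxy for fluoro on the strongest compound so far

The source may report more compounds than this note shows. Statements on the series, on what has been measured and on what is new or still open speak of the compounds shown alone.

In a functional assay on A549 cells (Homo sapiens) for antiproliferative activity, read by MTT assay, with a stated time of 24 h (a lower number here means a stronger inhibitor, a higher number a weaker inhibitor), compound 3 (`COc1ccc(S(=O)(=O)n2c(-c3cn(-c4ccccc4)nc3-c3ccc(C(F)(F)F)cc3)nc3ccccc32)cc1`) gives 170 nM and is the strongest of the three measured compounds. Compound 1 (`FC(F)(F)c1ccc(-c2nn(-c3ccccc3)cc2-c2nc3ccccc3[nH]2)cc1`) reads 3620 nM and compound 2 (`O=S(=O)(c1ccc(F)cc1)n1c(-c2cn(-c3ccccc3)nc2-c2ccc(F)cc2)nc2ccccc21`) reads 2370 nM on the same scale. One measured step reaches compound 3: (4-methoxyphenyl)sulfonyl in place of hydrogen on an aromatic nitrogen gives a 21-fold lower number from compound 1 to compound 3 (1.33 log units; beyond the scatter) and shows a large change at that group.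

Compound 4 (`O=S(=O)(c1ccc(F)cc1)n1c(-c2cn(-c3ccccc3)nc2-c2ccc(C(F)(F)F)cc2)nc2ccccc21`) keeps a sulfonyl group but has fluoro in place of methoxy on an aromatic carbon, so (4-methoxyphenyl)sulfonyl becomes (4-fluorophenyl)sulfonyl. Among the measured compounds shown here, no measured step isolates this swap. The nearest hint is compound 2, which also carries (4-fluorophenyl)sulfonyl and reads 2370 nM as a weaker number, though it is not a clean comparison. A moderate rise is therefore expected, namely a 2.9-fold higher number from compound 3 to compound 4 (0.47 log units; beyond the scatter) in this assay as an estimate. For compound 4 the estimated value is 500 nM with an expected range from 130 nM to 1900 nM as its limits.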

Compound 4, half-maximal inhibitory concentration: 1740 nM
Compound 4: the middle estimate sits 3.5-fold (0.54 log units) below what was measured; low and high end bracket the measured number.
By their numbers in this assay, from the lowest: compound 3; then compounds 4, 2 and 1 (each within the scatter of the next, the first and the last beyond it).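

The methoxy group, para to a large group, matters far more than its small size might suggest: in this assay, fluoro in its place gives a 10-fold higher number from compound 3 to compound 4 (1.01 log units; beyond the scatter). The sulfonyl group alone therefore does not explain the earlier gain, since adding (4-fluorophenyl)sulfonyl gives only a 2.1-fold lower number from compound 1 to compound 4 (0.32 log units; beyond the scatter), whereas adding (4-methoxyphenyl)sulfonyl gives a 21-fold lower number from compound 1 to compound 3 (1.33 log units; beyond the scatter). With (4-fluorophenyl)sulfonyl in place, trifluoromethyl in place of fluoro on the other ring gives a 1.4-fold lower number from compound 2 to compound 4 (0.13 log units; within the scatter), which is within the scatter, so this swap shows no real change.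

Nothing available here explains why methoxy and fluoro differ so sharply. As far as these compounds go, it remains open whether the benefit is specific to methoxy or would also appear with hydroxy, ethoxy or an amine at this position.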